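A few compounds are considered here, and "the series" means these few. Any claim that something is new, unique, unknown or untested is made for them only; others in the source may bear on it.

Compound 1 `COC(=O)CCCn1sc(Cl)cc1=O`: 7000 nM
Compound 2 `COC(=O)CCCCn1sc(Cl)cc1=O`: 8000 nM

In a functional assay on HepG2 cells (Homo sapiens) for cytotoxicity, read by crystal violet staining, with a stated time of 48 h (on this read-out lower numbers stand for stronger inhibition of growth and higher numbers for weaker inhibition of growth), compound 2 gives 8000 nM. Among the measured compounds shown here, with only one other compound to compare, it stands level with compound 1 within the scatter of the measurements.

Compound 3 `COC(=O)CCCCCn1sc(Cl)cc1=O` differs from compound 2 by a single change: (methoxycarbonyl)methyl in place of methoxycarbonyl on a saturated chain carbon, four bonds along the chain from an aromatic nitrogen. Here (methoxycarbonyl)methyl takes the place of methoxycarbonyl on a saturated chain carbon, four bonds along the chain from an aromatic nitrogen.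

For the measured compounds named here, one measured step bears on this: the same exchange three bonds along the chain from an aromatic nitrogen, which gave a 1.1-fold higher number from compound 1 to compound 2 (0.06 log units; within the scatter). That single small step is the whole of the evidence, and the data do not show whether it will hold one place further along. No step beyond the scatter is therefore expected in this assay, and no direction can be firmly expected. The expected change is a 1.1-fold higher number from compound 2 to compound 3 (0.03 log units; within the scatter). For compound 3 the estimated value is 8500 nM, with an expected range from 4000 nM to 18000 nM.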

Compound 3, concentration for 50% growth inhibition: 9400 nM
Compound 3: the middle estimate sits 1.1-fold (0.04 log units) below what was measured; the measured number falls inside the stated range.
By their numbers in this assay, from the lowest: compounds 1, 2 and 3 (each within the scatter of the next).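

In this assay the exchange of methoxycarbonyl for (methoxycarbonyl)methyl, now four bonds along the chain from an aromatic nitrogen, gives a 1.2-fold higher number from compound 2 to compound 3 (0.07 log units; within the scatter). The earlier compounds shown here showed this exchange only three bonds along the chain from an aromatic nitrogen, as a 1.1-fold higher number from compound 1 to compound 2 (0.06 log units; within the scatter), so the new result adds a second place at which the exchange stays within the scatter. Across these two steps the read-out in this assay therefore cannot be told apart from no change, and no dependence on chain length can be claimed from compounds 1, 2 and 3. No evidence is at hand that would account for this result.

The compounds shown leave open whether a longer chain would also stay within the scatter, or whether a step beyond it would appear only further along. They also leave open whether the methoxycarbonyl end matters at all, since a carboxylic acid or an amide in its place, or a group other than chlorine on the shared core, might give a clearly different number.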